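A few compounds are considered here, and "the series" means these few. Any claim that something is new, unique, unknown or untested is made for them only; others in the source may bear on it.

Measured so far in a functional assay on KB 3-1 cells (Homo sapiens) for cytotoxicity, read by MTT assay, with a stated time of 68 h; a higher number here means a weaker inhibitor, a lower number a stronger inhibitor:
compound 1 `O=C(Nc1cccc(-c2ccccc2C(F)(F)F)c1)C(Cl)Cl`: 35900 nM
compound 2 `O=C(Nc1cccc(-c2cccc(F)c2)c1)C(Cl)Cl`: > 50000 nM
compound 3 `COc1ccc(-c2cccc(NC(=O)C(Cl)Cl)c2)cc1`: > 50000 nM

Among the measured compounds shown here, compound 1 holds the only true number in this set. Compound 2 reads > 50000 nM, which is a limit of the assay and not a number. Compound 3 reads > 50000 nM, likewise a limit.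

Compound 4 `O=C(Nc1cccc(-c2ccccc2F)c1)C(Cl)Cl` has fluoro in place of trifluoromethyl on an aromatic carbon, ortho to a large group (fluoro in place of trifluoromethyl on an aromatic carbon). For the measured compounds named here, no measured step isolates this change. The expectation leans on compound 2, which also carries a fluoro and reads > 50000 nM. In this assay, the expected 1.3-fold higher number from compound 1 to compound 4 (0.10 log units; within the scatter) is no change beyond the scatter. For compound 4 the estimate is 45000 nM, with an expected range of 25000 nM to 50000 nM.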

Compound 4, half-maximal inhibitory concentration: 48300 nM
Beside the measured number, compound 4's estimate is 1.1-fold (0.03 log units) below it, and the stated range covers the measured number.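

In this assay, fluoro in place of trifluoromethyl, on an aromatic carbon ortho to a large group, gives a 1.3-fold higher number from compound 1 to compound 4 (0.13 log units; within the scatter). This first measured step at this position therefore shows no change beyond the scatter, so the smaller substituent and the larger one cannot be told apart here. Compound 4 reads as a true number, as compound 1 does, but little room remains for reading any weaker compound in this series: the limit of > 50000 nM in this assay, at which 2 of the 4 values shown sit.

Open, from the compounds shown here alone, is whether an amine or a carboxylic acid at this position would move the number beyond the scatter.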